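The compounds below may be only part of what the source reports. "The series", "measured", "known", "first", "only" and "open" are said of these compounds alone.

Measured so far in a functional assay on HepG2 cells (Homo sapiens) for antiproliferative activity, read by XTT assay, with a stated time of 72 h; on this read-out higher numbers stand for weaker inhibition and lower numbers for stronger inhibition:

compound 1, `Cc1nc(N)c2c(-c3cccs3)cn([C@@H]3O[C@H](CO)[C@@H](O)[C@H]3O)c2n1`: > 20000 nM, a limit of the assay rather than a number
compound 2, `COc1nc(N)nc2c1c(-c1cccs1)cn2[C@@H]1O[C@H](CO)[C@@H](O)[C@H]1O`: > 20000 nM, a limit of the assay rather than a number
compound 3, `Nc1nc(N)c2c(-c3cccs3)cn([C@@H]3O[C@H](CO)[C@@H](O)[C@H]3O)c2n1`: > 20000 nM, a limit of the assay rather than a number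

Among the compounds with values here, compound 3 stands at the limit in this assay, and the two other values shown stand at the same limit; the limit of > 20000 nM in this assay, at which 3 of the 3 values shown sit, holds every value so far. The two steps measured within the series, a step that the two limits leave unreadable from compound 1 to compound 3 and a step that the two limits leave unreadable from compound 2 to compound 3, are unreadable in size and direction because the limit of > 20000 nM in this assay, at which 3 of the 3 values shown sit, covers both ends of each.

Compound 4, `Nc1nc(N)c2c(-c3ccco3)cn([C@@H]3O[C@H](CO)[C@@H](O)[C@H]3O)c2n1`, differs from compound 3 in one place: furan-2-yl in place of thiophen-2-yl on an aromatic carbon. Neither measured step bears directly on this change, since both replace a group on a different aromatic carbon of the shared core and leave thiophen-2-yl untouched. Within the data shown here, the only guidance is that no value has yet fallen below the limit.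

The step that the limit leaves unreadable from compound 3 to compound 4 is therefore expected to be nothing readable, with compound 4 expected to sit at the limit as well. For compound 4 the estimate in this assay is 30000 nM, with a range from 12000 nM to 100000 nM.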

Compound 4, half-maximal inhibitory concentration: > 20000 nM
Compound 4: no number, only a limit; the forecaster's own chance of this, stated with the estimate: 85%; the middle value does not contradict the limit.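

The swap of thiophen-2-yl for furan-2-yl between compound 3 and compound 4 gives no readable step in this assay, because both values are limits of the assay and not numbers: the limit of > 20000 nM in this assay, at which 4 of the 4 values shown sit.

The compounds shown leave open whether any change on the shared core gives a measurable value, and how thiophen-2-yl and furan-2-yl compare.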